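The compounds below may be only part of what the source reports. "The series", "measured", "known", "first", "only" and "open" are said of these compounds alone.

Compound 1 `Oc1ccc(O)c(-c2cc(-c3ccccc3)nn2-c2ccccc2)c1` and compound 2 `NS(=O)(=O)c1ccc(-n2nc(-c3ccccc3)cc2-c2cc(O)ccc2O)cc1` share one core and differ in a single group. In a functional assay on cells (Cancer cell lines, Homo sapiens) for cytotoxicity, read by sulforhodamine B assay, with a stated time of 48 h (a lower number here means a stronger inhibitor of growth, a higher number a weaker inhibitor of growth), compound 1 gives 77400 nM, and compound 2 gives 100000 nM. Of these two numbers, the step of a 1.3-fold higher number from compound 1 to compound 2 (0.11 log units; within the scatter) lies within the scatter, so the two values stand together rather than apart. Compound 3 `CC(=O)NS(=O)(=O)c1ccc(-n2nc(-c3ccccc3)cc2-c2cc(O)ccc2O)cc1` arises from compound 2 by one change, (acetyl in place of hydrogen on a sulfonamide nitrogen). Among the measured compounds shown here, no measured step touches that sulfonamide nitrogen; the only step on record, a 1.3-fold higher number from compound 1 to compound 2 (0.11 log units; within the scatter), concerns a change on an aromatic carbon and was small. With nothing pointing either way, compound 3 is expected to stay close to compound 2, with an expected step of no change at the digits printed from compound 2 to compound 3 (within the scatter) of no size beyond the scatter. The estimate for compound 3 in this assay is therefore 100000 nM, expected to fall between 50000 nM and 200000 nM.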

Compound 3, concentration for total growth inhibition: 100000 nM
For compound 3 middle estimate and measured number coincide at the digits printed; low and high end bracket the measured number.
By their numbers in this assay, from the lowest: compounds 1, 2 and 3 (each within the scatter of the next).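

In this assay the sulfonamide nitrogen now has a measured step of its own: acetyl in place of hydrogen on that nitrogen gives no change at the digits printed from compound 2 to compound 3 (within the scatter) and so does not separate the two compounds. Placing the whole acetylsulfamoyl group on the aromatic carbon in place of hydrogen gives a 1.3-fold higher number from compound 1 to compound 3 (0.11 log units; within the scatter), so at this place neither the sulfamoyl group nor its acetylated form stands apart from hydrogen in this read-out. Nothing available explains this result.

Going by these compounds, it remains open whether a longer acyl chain or a benzoyl group on the sulfonamide nitrogen, or an amine or a carboxylic acid on the aromatic carbon, would give a step beyond the scatter. Also open, on these data alone, is what methoxy groups in place of the hydroxyl groups on the shared core would do.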